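This account rests on a few compounds, and the source may have more. Where it says the series, first, only, none or still open, it means among the compounds named here.

In a functional assay on MDA-MB-231 cells (Homo sapiens) for inhibition, read by MTT assay, with a stated time of 72 h (on this read-out higher numbers stand for weaker inhibition and lower numbers for stronger inhibition), compound 1 `CC1=NN(c2ccccc2)C(=O)[C@]12C(=O)C=CC[C@H]2c1ccc(C)cc1` gives 5720 nM. Its mirror image, compound 2 `CC1=NN(c2ccccc2)C(=O)[C@@]12C(=O)C=CC[C@@H]2c1ccc(C)cc1`, gives 7420 nM. Among the compounds with values here, the two numbers lie within the scatter of each other, so no order can be read between the only two measured compounds. Next is compound 3 `CC1=NN(c2ccc(C)cc2)C(=O)[C@]12C(=O)C=CC[C@H]2c1ccc(C)cc1`, which keeps the configuration of compound 1 as drawn and carries methyl in place of hydrogen on an aromatic carbon, para to a large group, with phenyl becoming 4-methylphenyl. Within the data shown here, the one measured step, a 1.3-fold higher number from compound 1 to compound 2 (0.11 log units; within the scatter), comes with the fact that compounds 1 and 2 differ only in the configuration as drawn. Among the measured compounds shown here, that step involves no change on an aromatic carbon, so it sets no size for the methyl change, and no measured pair tests a substituent on this ring. With nothing pointing either way, no shift beyond the scatter is expected in this assay, although support for this expectation is thin. The expected step is a 1.0-fold lower number from compound 1 to compound 3 (0.02 log units; within the scatter). For compound 3 the estimated value is 5500 nM, with an expected range of 2300 nM to 13000 nM.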

Compound 3, half-maximal inhibitory concentration: 8280 nM
The estimate for compound 3 lay 1.5-fold (0.18 log units) below the measured number, and the stated range covers the measured number.
By their numbers in this assay, from the lowest: compounds 1, 2 and 3 (each within the scatter of the next).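

In this assay, methyl in place of hydrogen on an aromatic carbon, para to a large group, with phenyl becoming 4-methylphenyl, gives a 1.4-fold higher number from compound 1 to compound 3 (0.16 log units; within the scatter). Within the data shown here, this is the first measured read on a substituent at this ring position, and it shows that a single added methyl there leaves the number in the same range as compound 1, with no shift that can be read beyond the scatter. Nothing on hand bears on the size of this step.

What the compounds shown leave open is whether this position stays as flat for groups other than methyl: an amine, a carboxylic acid, a methoxy group or a longer chain such as butyl in the same place could still move the number beyond the scatter, and a single small alkyl group says nothing about any of them. Also open is whether the mirror-image pair stays within the scatter once 4-methylphenyl replaces phenyl, since the only pair of mirror images shown carries phenyl.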